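Hydroxy in place of trifluoromethyl on the anilino ring

A few compounds are considered here, and "the series" means these few. Any claim that something is new, unique, unknown or untested is made for them only; others in the source may bear on it.

Compound 3 `O=C(/C=C\Nc1ccc(C(F)(F)F)cc1)c1cn(-c2ccccc2)nc1-c1ccc(F)cc1` sits at the edge of what a functional assay on PC-3 cells (Homo sapiens) for antiproliferative activity, read by MTT assay, with a stated time of 48 h (a lower number here means a stronger inhibitor, a higher number a weaker inhibitor), can report: in this assay compound 3 gives > 50000 nM, which is a limit of the assay and not a number. Compound 2 `O=C(/C=C\Nc1ccc(F)cc1)c1cn(-c2ccccc2)nc1-c1ccc(F)cc1`, carrying fluoro on the same ring, gives 7900 nM in this assay. The measured step is an at least 6.3-fold higher number from compound 2 to compound 3 (0.80 log units; beyond the scatter); its size is known only as a bound because of the limit of > 50000 nM in this assay, at which 1 of the 3 values shown sits. Within the data shown here, compound 1 `O=C(/C=C\Nc1ccc(O)cc1)c1cn(-c2ccccc2)nc1-c1ccccc1`, which carries hydroxy on that ring but no fluoro on the other phenyl, gives 3600 nM in this assay; it differs from compound 2 and compound 3 in more than one place, so no single step is drawn to it.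

The change to compound 4 `O=C(/C=C\Nc1ccc(O)cc1)c1cn(-c2ccccc2)nc1-c1ccc(F)cc1` is hydroxy in place of trifluoromethyl on an aromatic carbon, on an aromatic carbon of a six-membered aromatic ring of carbon only, para to a large group. Among the measured compounds shown here, the only measured step on this ring runs the other way, from fluoro to trifluoromethyl, and was at least modest toward weaker inhibition; removing trifluoromethyl is therefore expected to move the number down, by an estimated at least 10-fold lower number from compound 3 to compound 4 (1.00 log units; beyond the scatter). Compound 1, with hydroxy on this ring, gives 3600 nM, which points the same way. Compound 4 is expected to give about 5000 nM, estimated between 1800 nM and 15000 nM.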

Compound 4, half-maximal inhibitory concentration: 2600 nM
The estimate for compound 4 lay 1.9-fold (0.28 log units) above the measured number; low and high end bracket the measured number.
By their numbers in this assay, from the lowest: compounds 4 and 1 (each within the scatter of the next); then compound 2. At a limit, above all of these: compound 3.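

On the ring that carries the amino link, with fluoro held on the other phenyl, three groups can now be ranked in this assay: hydroxy in place of fluoro gives a 3.0-fold lower number from compound 2 to compound 4 (0.48 log units; beyond the scatter), so this position takes hydroxy better than either halogen-bearing group tested. Against trifluoromethyl the change gives an at least 19-fold lower number from compound 3 to compound 4 (1.28 log units; beyond the scatter), but the value of compound 3 is a limit and not a number, so the size is only a bound: the limit of > 50000 nM in this assay, at which 1 of the 4 values shown sits. With hydroxy held on this ring, fluoro in place of hydrogen on the other phenyl gives a 1.4-fold lower number from compound 1 to compound 4 (0.14 log units; within the scatter), so no effect of that fluoro can be read here.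

Open, on these data alone, is how methoxy, an amine or a carboxylic acid would read on this ring, and whether hydroxy elsewhere on it would match. Also open, as far as these compounds go, is whether fluoro on the other phenyl stays without effect alongside other groups on this ring.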